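The source may report more compounds than this note shows. Statements on the series, on what has been measured and on what is new or still open speak of the compounds shown alone.

Measured compounds:
- compound 1, `OCc1cc(O)c(O)c(Br)c1`: "not determined" (no result reported) in a functional assay on HCT-116 cells (Homo sapiens) for cytotoxicity, read by MTT assay, with a stated time of 96 h; on this read-out lower numbers stand for stronger inhibition and higher numbers for weaker inhibition
- compound 2, `COCc1cc(Br)c(O)c(O)c1Br`: 3480 nM
- compound 3, `CCCOCc1cc(O)c(O)c(Br)c1`: "not determined" (no result reported)

Compound 1 has no number of its own in this assay; compound 3 is likewise without a result, so the only figure in this small set comes from compound 2, which gives 3480 nM in this assay. Compound 1 therefore cannot be placed on a scale; it stands among the entries for which nothing was reported.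

The step from compound 1 leads to compound 4, `OCc1cc(O)c(O)c(Br)c1Br`, which is still to be measured in this assay. The change is bromo in place of hydrogen on an aromatic carbon. Compound 4 thus carries two bromo groups on the shared core, as compound 2 does, while keeping the hydroxymethyl group of compound 1.

Among the measured compounds shown here, with no measured pair of neighbouring compounds to lean on, the size of the step from compound 1 to compound 4 cannot be read from the data; any expectation for it rests only on compound 2, which gives 3480 nM in this assay and shares the two bromo groups. Compound 4 is expected to land near that figure, about 4000 nM, with a range from 1200 nM to 14000 nM.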

Compound 4, half-maximal inhibitory concentration: 20400 nM
Beside the measured number, compound 4's estimate is 5.1-fold (0.71 log units) below it; measured number above the stated range.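

Compound 1 has no single number in this assay, and compound 4 differs from compound 2 in more than one place, so no new step can be read for compound 4. As far as these compounds go, what the added bromo group does to the cytotoxicity of compound 1 stays open. Nothing shown here offers an explanation for the result of compound 4.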